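The source may hold more compounds than are shown below. What is called first, only, known or untested is meant among the compounds shown, and "the series" means these compounds.

Compound 1, `CC1(C)N(O)C(c2ccc(OCC(=O)N[C@@H](CCCCN)C(=O)O)cc2)=[N+]([O-])C1(C)C`, gives 30100 nM in a functional assay on PC-12 cells (Rattus norvegicus) for inhibition, read by MTT assay; on this read-out lower numbers stand for an effect already at smaller amounts and higher numbers for an effect only at larger amounts of compound.
Compound 2, `CC1(C)N(O)C(c2ccc(OCC(=O)NCCCC[C@H](N)C(=O)O)cc2)=[N+]([O-])C1(C)C`, gives 29900 nM in this assay.
Compound 3, `CC(C)(C)OC(=O)N[C@@H](CCCCNC(=O)COc1ccc(C2=[N+]([O-])C(C)(C)C(C)(C)N2O)cc1)C(=O)O`, gives 29300 nM in this assay.

Compound 2 stands in the middle of the three numbers, with compound 1 nearest and compound 3 furthest, both separated from it by less than the scatter; the three compounds are indistinguishable on this read-out. Compound 4, `CC1(C)N(O)C(c2ccc(OCC(=O)N[C@@H](CCCNC(=N)N)C(=O)O)cc2)=[N+]([O-])C1(C)C`, is the next compound. The change from compound 2 to compound 4 is a group of 11 heavy atoms (6 carbon, 3 nitrogen, 2 oxygen; no ring) in place of a group of 9 heavy atoms (6 carbon, 1 nitrogen, 2 oxygen; no ring), on an amide-type nitrogen. Among the compounds with values here, two measured steps bear on it: a 1.0-fold lower number from compound 1 to compound 2 (0.00 log units; within the scatter), and a 1.0-fold lower number from compound 2 to compound 3 (0.01 log units; within the scatter). Both alter the group on the same amide-type nitrogen or its amine end and leave the number where it was, so the shared core appears to set the value while the chain on that nitrogen does not move it. No step beyond the scatter is therefore expected in this assay for compound 4, in either direction. Compound 4 is estimated to give 30000 nM, with a range from 15000 nM to 60000 nM. The expected step is accordingly a 1.0-fold higher number from compound 2 to compound 4 (0.00 log units; within the scatter), within the scatter.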

Compound 4, half-maximal effective concentration: 32100 nM
Beside the measured number, compound 4's estimate is 1.1-fold (0.03 log units) below it; the range from low to high includes it.
By their numbers in this assay, from the lowest: compounds 3, 2, 1 and 4 (each within the scatter of the next).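

In this assay the group on the amide-type nitrogen now changes at its far end too, and the read-out still holds: there is a 1.1-fold higher number from compound 2 to compound 4 (0.03 log units; within the scatter), and a 1.1-fold higher number from compound 1 to compound 4 (0.03 log units; within the scatter). The second step is a change on a saturated chain carbon, four bonds along the chain from an amide-type nitrogen and a carbonyl carbon, a kind of change that compound 1, compound 2 and compound 3 did not cover, and it too stays within the scatter. Nothing given here accounts for this flat result.

The compounds shown leave open whether a group of another kind on this nitrogen, such as a benzyl group or a plain methyl, would move the number. They also leave open whether the same holds once the shared core itself is changed.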